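Swapping the bromophenyl arm for a pyridine ring

The source may hold more compounds than are shown below. What is called first, only, known or untested is meant among the compounds shown, and "the series" means these compounds.

Measured so far:
- compound 1, `CC(=O)N1N=C(c2ccc3ccccc3c2)OC1c1ccccc1Br`: 5.49 ug/mL
- compound 2, `CC(=O)N1N=C(c2ccc3ccccc3c2)OC1c1ccccc1[N+](=O)[O-]`: 18.2 ug/mL

Both compounds were tested in a functional assay on MCF7 cells (Homo sapiens) for antiproliferative activity, read by MTT assay, with a stated time of 48 h; on this read-out lower numbers stand for stronger inhibition and higher numbers for weaker inhibition. Compound 1, with its 2-bromophenyl group, gives the lowest of the two numbers; its nearest neighbour is compound 2, reached by a 3.3-fold higher number from compound 1 to compound 2 (0.52 log units; beyond the scatter). Among the compounds with values here, that single step is the only measured change at this position, and it shows that replacing the halogen on that ring shifts the number by a modest but real amount.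

Compound 3, `CC(=O)N1N=C(c2ccc3ccccc3c2)OC1c1ccccn1`, has not yet been measured. It differs from compound 1 by pyridin-2-yl in place of 2-bromophenyl on a saturated ring carbon. Within the data shown here, no measured pair shows this exact change, so the bromo-to-nitro step is the only guide; it suggests the number at this position can move upward when the bromophenyl group is altered, but a whole-ring exchange is a larger change than a substituent swap and could go either way. The expected outcome is a small upward shift, a 1.6-fold higher number from compound 1 to compound 3 (0.21 log units; within the scatter), with compound 3 estimated at 9 ug/mL, within a range from 3 ug/mL to 30 ug/mL.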

Compound 3, half-maximal inhibitory concentration: 6.02 ug/mL
The estimate for compound 3 lay 1.5-fold (0.17 log units) above the measured number; the range from low to high includes it.
By their numbers in this assay, from the lowest: compounds 1 and 3 (each within the scatter of the next); then compound 2.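

Within the data shown here, measured in this assay the whole ring exchange is the first change at this saturated ring carbon that leaves the number in place: the step is a 1.1-fold higher number from compound 1 to compound 3 (0.04 log units; within the scatter) and so gives no separation between the two compounds. The bromine is therefore not required to reach the level of compound 1, since a pyridin-2-yl ring, which carries no halogen at all, does as well in this read-out. The second step, a 3.0-fold lower number from compound 2 to compound 3 (0.48 log units; beyond the scatter), adds that compound 2 is the one that stands apart among the three, so the higher number goes with the 2-nitrophenyl group in particular and not with any departure from 2-bromophenyl; nothing available explains these differences, so they stand as observations without a cause.

Still open, going by these compounds, is what a plain phenyl ring with no substituent would give, which would show whether the bromine and the ring nitrogen each contribute anything or whether the bare ring already reaches this level. An amine or a carboxylic acid on that ring would also test how widely the position tolerates change, and how far the nitro result extends to other groups.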